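The source may hold more compounds than are shown below. What is called first, only, known or untested is meant among the compounds shown, and "the series" means these compounds.

Measured in a functional assay on V79 cells (Cricetulus griseus) for cytotoxicity, read by colony formation; on this read-out lower numbers stand for stronger inhibition and higher numbers for weaker inhibition:
- compound 1 `CC1CN(c2c(F)cc3c(=O)c(C(=O)O)cn(C4CC4)c3c2F)CC(C)N1`: 150 ug/mL
- compound 2 `NC1CCN(c2c(F)cc3c(=O)c(C(=O)O)cn(C4CC4)c3c2F)CC1`: 23 ug/mL

Compound 2 has the lower of the two numbers in this assay. Compound 3 `NC1CCCN(c2c(F)cc3c(=O)c(C(=O)O)cn(C4CC4)c3c2F)C1` carries 3-aminopiperidin-1-yl in place of 4-aminopiperidin-1-yl on an aromatic carbon. Among the measured compounds shown here, only one measured step bears on this, a 6.5-fold lower number from compound 1 to compound 2 (0.81 log units; beyond the scatter), and it exchanged a different group altogether. Here the same atoms are joined differently, so a smaller change is expected, with a slight upward drift at most. The estimated change is a 1.4-fold higher number from compound 2 to compound 3 (0.14 log units; within the scatter), and no shift beyond the scatter is expected. For compound 3 the estimate is 32 ug/mL, with an expected range of 11 ug/mL to 95 ug/mL.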

Compound 3, half-maximal inhibitory concentration: 53 ug/mL
Beside the measured number, compound 3's estimate is 1.7-fold (0.22 log units) below it; low and high end bracket the measured number.
By their numbers in this assay, from the lowest: compound 2; then compound 3; then compound 1.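

In this assay, the swap of 4-aminopiperidin-1-yl for 3-aminopiperidin-1-yl, with the same atoms joined differently, gives a 2.3-fold higher number from compound 2 to compound 3 (0.36 log units; beyond the scatter), so the read-out at this aromatic carbon depends on how the amine sits on the ring, not only on which atoms the group holds. Compound 3 still keeps a 2.8-fold lower number from compound 1 to compound 3 (0.45 log units; beyond the scatter), which places both aminopiperidines below the 3,5-dimethylpiperazin-1-yl compound. Nothing at hand accounts for the shift between the two isomers. Open, as far as these compounds go, is whether a 3-aminopyrrolidin-1-yl or an unsubstituted piperazin-1-yl at this position would fall within this range.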